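Sulfophenyl for tert-butyl on the pyrazolone nitrogen

The source may hold more compounds than are shown below. What is called first, only, known or untested is meant among the compounds shown, and "the series" means these compounds.

Measured compounds:
- compound 1, `O=C(O)c1cccc2c(/N=N/c3c(O)cc(S(=O)(=O)O)c4ccccc34)c(O)ccc12`: in an assay on BaF3 cells with thrombopoietin receptor (Homo sapiens) as the target, read by a luciferase reporter (on this read-out higher numbers stand for larger maximal responses and lower numbers for smaller maximal responses), it reaches < 5%
- compound 2, `Cc1[nH]n(C(C)(C)C)c(=O)c1/N=N/c1c(O)cc(S(=O)(=O)O)c2ccccc12`: in this assay it reaches < 5%

Compound 1 gives only a limit of the assay, not a number: < 5%. Compound 2 likewise gives only a limit, < 5%, and so it stands at the floor of the numbers shown, as the limit of < 5% in this assay, at which 2 of the 2 values shown sit, records. Among the compounds with values here, neither compound shows a measurable maximal response, and no step between them can be sized.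

Compound 3, `Cc1[nH]n(-c2ccc(S(=O)(=O)O)cc2)c(=O)c1/N=N/c1c(O)cc(S(=O)(=O)O)c2ccccc12`, has not yet been measured. It differs from compound 2 in one place: 4-sulfophenyl in place of tert-butyl on an aromatic nitrogen

Within the data shown here, no measured step with this kind of change exists here, so the expectation rests on compound 2 alone. Since compound 2 sits at the limit, the step that the limit leaves unreadable from compound 2 to compound 3 is expected to be none beyond the scatter, with compound 3 most likely again reported only as a limit. Compound 3 is estimated to reach 3%, within 0% to 15%, in this assay.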

Compound 3, largest response reached (reported as efficacy), in percent of the reference or control that the assay uses: < 5%
Compound 3 ended at the assay's limit; the forecaster's own chance of this, stated with the estimate: 75%; the middle value does not contradict the limit.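

Going from tert-butyl in compound 2 to 4-sulfophenyl in compound 3 gives no step that can be read, because both values are limits of the assay and not numbers: the limit of < 5% in this assay, at which 3 of the 3 values shown sit.

The compounds shown leave open whether any change to them can give a measurable maximal response in this assay at all, and which part of the structure would matter for one.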